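Benzyl carbamate in place of the tert-butyl carbamate

A few compounds are considered here, and "the series" means these few. Any claim that something is new, unique, unknown or untested is made for them only; others in the source may bear on it.

Compound 1 `Cn1cncc1CN1CC(N(CC2CCN(C(=O)OC(C)(C)C)CC2)S(=O)(=O)c2ccccn2)Cc2cc(C#N)ccc21` was measured in an ADME assay on Caco-2 cells (Homo sapiens) for permeability, in the apical to basolateral direction (on this read-out lower numbers stand for lower permeability and higher numbers for higher permeability), and gave 15.5 10^-6 cm/s. Among the two measured compounds this is the highest number; its nearest neighbour is compound 2 `CCOC(=O)N1CCC(CN(C2Cc3cc(C#N)ccc3N(Cc3cncn3C)C2)S(=O)(=O)c2ccccn2)CC1`, which in this assay gave 2.6 10^-6 cm/s. Within the data shown here, the one measured step that touches the same place is a 6.0-fold lower number from compound 1 to compound 2 (0.78 log units; beyond the scatter), a modest change brought about by ethyl in place of tert-butyl on an oxygen next to a carbonyl group.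

Compound 3 `Cn1cncc1CN1CC(N(CC2CCN(C(=O)OCc3ccccc3)CC2)S(=O)(=O)c2ccccn2)Cc2cc(C#N)ccc21` has not yet been measured in this assay. It differs from compound 1 as follows: benzyl in place of tert-butyl on an oxygen next to a carbonyl group. The step from compound 1 to compound 2 bears on this change in that the same position is altered, but there the group became smaller, while in compound 3 a seven-carbon benzyl enters for a four-carbon tert-butyl, so that step cannot be carried over directly. Among the measured compounds shown here, with only one step at this position to lean on, the expected movement for compound 3 in this assay is a small one, a 1.6-fold lower number from compound 1 to compound 3 (0.19 log units; within the scatter), possibly within the scatter. Compound 3 is therefore expected to give about 10 10^-6 cm/s, with a range from 4 10^-6 cm/s to 25 10^-6 cm/s.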

Compound 3, apparent permeability: 1 10^-6 cm/s
Compound 3: the middle estimate sits 10-fold (1.00 log units) above what was measured; the measured number lies below the stated range.
By their numbers in this assay, from the lowest: compound 3; then compound 2; then compound 1.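

At this position, on an oxygen next to a carbonyl group, a larger group now also gives a lower number in this assay: benzyl, with seven carbons and a six-membered aromatic ring, entering for the four-carbon tert-butyl gives a 16-fold lower number from compound 1 to compound 3 (1.19 log units; beyond the scatter), a larger step in the same direction as the smaller ethyl gave in a 6.0-fold lower number from compound 1 to compound 2 (0.78 log units; beyond the scatter). The benzyl compound also falls below the ethyl compound, with phenyl in place of methyl on a saturated chain carbon bound to an oxygen next to a carbonyl group giving a 2.6-fold lower number from compound 2 to compound 3 (0.41 log units; beyond the scatter), so across these three compounds the number does not follow the size of the group, and tert-butyl stands above both a smaller and a larger group. Nothing shown here accounts for this order.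

The compounds shown leave open how isopropyl or cyclohexylmethyl on this oxygen would compare with tert-butyl, and so whether the high number of compound 1 is particular to tert-butyl. They also leave open whether a phenyl directly on this oxygen, or an amide nitrogen in place of the oxygen, would stay close to compound 3 or move away from it.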